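This account rests on a few compounds, and the source may have more. Where it says the series, first, only, none or still open, it means among the compounds named here.

Compound 1 `CCC/N=C(\S)OC[C@H]1OC(n2cnc3c(NC4CCOC4)ncnc32)[C@H](O)[C@@H]1O`: 50 nM
Compound 2 `O[C@@H]1[C@@H](CO/C(S)=N/C2CCCC2)OC(n2cnc3c(NC4CCOC4)ncnc32)[C@@H]1O`: 72 nM

Compound 2 has the higher of the two numbers in an assay on DDT1 cells (Cricetulus griseus) for binding affinity to adenosine receptor A1 (Homo sapiens), read by radioligand binding (a lower number here means a stronger inhibitor, a higher number a weaker inhibitor), but its distance to compound 1, a 1.4-fold higher number from compound 1 to compound 2 (0.16 log units; within the scatter), lies within the scatter. Compound 3 `CN(C)C(=S)OC[C@H]1OC(n2cnc3c(NC4CCOC4)ncnc32)[C@H](O)[C@@H]1O` is not yet measured; it differs from compound 2 by a group of 5 heavy atoms (3 carbon, 1 nitrogen, 1 sulfur; no ring) in place of a group of 8 heavy atoms (6 carbon, 1 nitrogen, 1 sulfur; one five-membered non-aromatic ring of carbon only), on an oxygen on a saturated carbon. Among the measured compounds shown here, the only measured step at this position, a 1.4-fold higher number from compound 1 to compound 2 (0.16 log units; within the scatter), swapped one group on the double-bonded nitrogen for another without moving the number beyond the scatter. The present change is broader, so that step is only a loose guide. A step of a 1.8-fold higher number from compound 2 to compound 3 (0.26 log units; within the scatter) toward a higher number is expected. Compound 3 is estimated at 130 nM, with a range from 40 nM to 450 nM.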

Compound 3, inhibition constant: 205 nM
Compound 3: the middle estimate sits 1.6-fold (0.20 log units) below what was measured; low and high end bracket the measured number.
By their numbers in this assay, from the lowest: compounds 1 and 2 (each within the scatter of the next); then compound 3.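

In this assay, this position, on an oxygen on a saturated carbon, now shows a change beyond the scatter: a 2.8-fold higher number from compound 2 to compound 3 (0.45 log units; beyond the scatter) and a 4.1-fold higher number from compound 1 to compound 3 (0.61 log units; beyond the scatter). Against compound 2, the entering group has no ring and 0 hydrogen-bond donors, where the leaving group has a five-membered ring and 1 donor. No measurement on hand accounts for the shift.

Which of these two differences matters remains open. Also open, going by these compounds, is how a longer chain such as hexyl, or a phenyl ring, on the nitrogen would read.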